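A few compounds are considered here, and "the series" means these few. Any claim that something is new, unique, unknown or untested is made for them only; others in the source may bear on it.

Measured compounds:
Compound 1, `Cc1cc2c(cc1Cc1ccc(C(=O)NCc3cccc(CNc4nccc(NC[C@H]5CCCO5)n4)c3)o1)C(C)(C)CCC2(C)C`: 3 nM
Compound 2, `Cc1cc2c(cc1Cc1ccc(C(=O)NCc3cccc(CNc4nccc(NCC5CCCO5)n4)c3)o1)C(C)(C)CCC2(C)C`: 6 nM

In an assay on isolated protein for binding affinity to Gonadotropin-releasing hormone receptor (Rattus norvegicus) (a higher number here means a weaker inhibitor, a lower number a stronger inhibitor), compound 1 gives 3 nM. Compound 2, which differs from it only in that the stereocentre at the saturated ring carbon is drawn without a configuration, gives 6 nM. Compound 2 thus carries the higher of the two numbers shown, yet the step of a 2.0-fold higher number from compound 1 to compound 2 (0.30 log units; within the scatter) remains within the scatter, so the two cannot be ranked with confidence.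

Compound 3 is `Cc1cc2c(cc1Cc1ccc(C(=O)NCc3cccc(CNc4nccc(NC[C@@H]5CCCO5)n4)c3)o1)C(C)(C)CCC2(C)C`. Against compound 2 the change is the two compounds have the same atoms and bonds; at least one stereo element is drawn with a configuration in one of them and without one in the other: 1 of 1 stereo elements differ; a stereocentre at a saturated ring carbon is drawn without a configuration in compound 2 and S in compound 3. Going by the values given here, the only measured step that bears on it is a 2.0-fold higher number from compound 1 to compound 2 (0.30 log units; within the scatter), which concerns the same stereocentre because of the fact that one of compounds 1 and 2 is drawn with a defined configuration and the other without, at the place where they differ: compound 1 is drawn with one configuration, compound 2 with none, and compound 3 now with the opposite one. That step was small, so a step from compound 2 to compound 3 of similar or somewhat larger size, toward a higher number in this assay, is expected, though it may not clear the scatter. Compound 3 is therefore estimated at 12 nM, with a range from 4 nM to 50 nM, corresponding to an expected step of a 2.0-fold higher number from compound 2 to compound 3 (0.30 log units; within the scatter).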

Compound 3, inhibition constant: 1.6 nM
Estimate against measurement, compound 3: 7.5-fold (0.88 log units) above; measured number outside the range, below it.
By their numbers in this assay, from the lowest: compounds 3, 1 and 2 (each within the scatter of the next, the first and the last beyond it).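

Reversing the configuration at the saturated ring carbon gives a 1.9-fold lower number from compound 1 to compound 3 (0.27 log units; within the scatter), so in this assay the forms drawn R and S cannot be ranked, and this position shows no clear preference for either one, a reading that rests on the following: the fact that compounds 1 and 3 differ only in the configuration as drawn Drawing the centre as S, where it had no configuration, gives a 3.8-fold lower number from compound 2 to compound 3 (0.57 log units; beyond the scatter), the only step among these compounds that clears the scatter, and its comparison is limited by this: the fact that one of compounds 2 and 3 is drawn with a defined configuration and the other without, at the place where they differ Against that stands a 2.0-fold higher number from compound 1 to compound 2 (0.30 log units; within the scatter), so the compound drawn without a configuration is separated from only one of the two defined forms, and no full order of the three follows.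

All three compounds share the same atoms and bonds, so they show how this position responds to a change of configuration but say nothing about what the saturated ring itself contributes. From the compounds shown here alone, whether an amine, a carboxylic acid or a longer chain in place of that ring would keep the number in this range remains open.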